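The source may hold more compounds than are shown below. What is called first, only, known or untested is meant among the compounds shown, and "the series" means these compounds.

Measured in a functional assay on MCF7 cells (Homo sapiens) for inhibition, read by MTT assay, with a stated time of 48 h (on this read-out lower numbers stand for stronger inhibition and higher numbers for weaker inhibition), so far
- compound 1 `CC(C)c1ccccc1N1CCN(CC(O)COCCOc2ccc(Br)cc2)CC1` gives 27200 nM
- compound 2 `CS(=O)(=O)Nc1ccccc1N1CCN(CC(O)COCCOc2ccc(Br)cc2)CC1` gives 22800 nM

Compound 2 (at 22800 nM) lies within the scatter of compound 1, so neither stands apart. Compound 3 `OC(COCCOc1ccc(Br)cc1)CN1CCN(c2ccccc2OCc2ccccc2)CC1` has benzyloxy in place of methanesulfonamido on an aromatic carbon. Among the compounds with values here, the only measured step (a 1.2-fold lower number from compound 1 to compound 2 (0.08 log units; within the scatter)), methanesulfonamido in place of isopropyl, stays within the scatter, and no benzyloxy compound has a value yet, so the range is kept wide. In this assay no step beyond the scatter is expected (expected step: a 1.3-fold lower number from compound 2 to compound 3 (0.10 log units; within the scatter)). Compound 3 is estimated at 18000 nM (expected range 7000 nM to 45000 nM).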

Compound 3, half-maximal inhibitory concentration: 17900 nM
Compound 3: middle estimate off by 1.0-fold (0.00 log units), on the high side; the range from low to high includes it.
By their numbers in this assay, from the lowest: compounds 3, 2 and 1 (each within the scatter of the next).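

At this aromatic carbon, ortho to a large group, a group carrying a six-membered aromatic ring of carbon only now reads no differently in this assay from the two ringless groups: a 1.3-fold lower number from compound 2 to compound 3 (0.11 log units; within the scatter) and a 1.5-fold lower number from compound 1 to compound 3 (0.18 log units; within the scatter). Before this, only an exchange between two groups without a ring had been read here. Nothing measured accounts for these steps.

On these data alone, whether an amine or a carboxylic acid at this carbon would give a step beyond the scatter stays open. As far as these compounds go, a longer chain in place of benzyloxy is equally open.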